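A few compounds are considered here, and "the series" means these few. Any claim that something is new, unique, unknown or untested is made for them only; others in the source may bear on it.

Measured so far in a functional assay on the whole organism (plasma, strain Sprague-Dawley) with Rattus norvegicus as the target, with a stated time of 2 h, at a dose of 100 mg/kg by the oral route; a lower number here means a weaker effect, a higher number a stronger effect of the compound at the dose given:
Compound 1 `c1ccc(C(/N=C2\CCCCN2)c2ccco2)cc1`: 27%
Compound 2 `c1ccc(C(/N=C2\CCCCCN2)c2ccco2)cc1`: 52%
Compound 3 `c1ccc(C(/N=C2\CCCCN2)c2cccs2)cc1`: 32%

Compound 1 and compound 3 share one core and differ in a single place: thiophen-2-yl in place of furan-2-yl on a saturated chain carbon bound to an aromatic carbon and a double-bonded nitrogen. That change gave a number 5 percentage points higher from compound 1 to compound 3 (within the scatter), so the two numbers cannot be told apart. Compound 2 stands highest of the three: its number lies beyond the scatter from compound 3 and from compound 1. How the core of compound 2 differs from the core of compound 1 is not broken down here.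

Compound 4 `c1ccc(C(/N=C2\CCCCCN2)c2cccs2)cc1` has not yet been measured in this assay. It differs from compound 2 by the same kind of change, made at the same place: thiophen-2-yl in place of furan-2-yl on a saturated chain carbon bound to an aromatic carbon and a double-bonded nitrogen. Among the compounds shown this change occurs twice. The step from compound 2 to compound 4 is expected to be small, a number 4 percentage points higher from compound 2 to compound 4 (within the scatter), because the earlier step of the same kind was a number 5 percentage points higher from compound 1 to compound 3 (within the scatter). For compound 4 the expected value in this assay is therefore 56%, with a likely range from 40% to 72%.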

Compound 4, a percentage reported as inhibition, in the whole organism at one dose (the size of the read-out at that dose, not a potency): 50%
For compound 4 the middle estimate is 6 percentage points above the measured one, and the stated range covers the measured number.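

On the core of compound 2, replacing furan-2-yl with thiophen-2-yl gave a number 2 percentage points lower from compound 2 to compound 4 (within the scatter) in this assay. Set beside the earlier step, the change carries from one core to the other with no difference that can be told apart: the same change on two cores in this assay, a number 5 percentage points higher (within the scatter) from compound 1 to compound 3 and a number 2 percentage points lower (within the scatter) from compound 2 to compound 4, 7 percentage points apart, within the scatter of two such steps. This shows that on these two cores, at the single dose used, furan-2-yl and thiophen-2-yl cannot be told apart in this read-out, but two pairs do not show that the same would hold on any other core, or that the two groups match in anything beyond this number.

The compounds shown leave open whether a different group on the saturated chain carbon bound to an aromatic carbon and a double-bonded nitrogen, such as an amine, a carboxylic acid or pyridin-2-yl, would move the number beyond the scatter. They also leave open how the inhibition changes with dose, since each compound is seen at one dose and one time only.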